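Swapping the aryl group on a thiourea-bearing core

The compounds below may be only part of what the source reports. "The series", "measured", "known", "first", "only" and "open" are said of these compounds alone.

Three compounds share a core and differ only in the aryl group on the urea-type nitrogen. Compound 1 `COc1cccc(NC(=S)NC2CC(C)(C)Oc3ccc(Br)cc32)c1` carries a 3-methoxyphenyl and gives 87000 nM in a functional assay on T98G cells (Homo sapiens) for inhibition, read by MTT assay, with a stated time of 72 h; a lower number here means a stronger inhibitor, a higher number a weaker inhibitor. Compound 2 `COc1ccccc1NC(=S)NC1CC(C)(C)Oc2ccc(Br)cc21` carries a 2-methoxyphenyl and gives 42000 nM in this assay. Compound 3 `CC1(C)CC(NC(=O)Nc2cccc(Cl)c2)c2cc(Br)ccc2O1`, a urea with a 3-chlorophenyl, gives 67000 nM in this assay. For the measured compounds named here, the one single-point step measured so far, a 2.1-fold lower number from compound 1 to compound 2 (0.32 log units; beyond the scatter), is modest. Compound 2 sits beyond the scatter below compound 1 but within the scatter of compound 3, so nothing separates compound 2 from compound 3 on these numbers.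

Compound 4 `CC1(C)CC(NC(=S)Nc2ccc(Cl)cc2)c2cc(Br)ccc2O1` is the next member. Compared with compound 2 the change is 4-chlorophenyl in place of 2-methoxyphenyl on an amide-type nitrogen. Going by the values given here, no measured step places a 4-chlorophenyl on the thiourea nitrogen; the only step that bears on an aryl change, a 2.1-fold lower number from compound 1 to compound 2 (0.32 log units; beyond the scatter), was small, and compound 3, which combines a chlorophenyl with a different linker, lies within the scatter of compound 2. The expectation for compound 4 is therefore a step of about a 1.1-fold higher number from compound 2 to compound 4 (0.03 log units; within the scatter), that is, none beyond the scatter. Compound 4 is estimated at 45000 nM, in the range 15000 nM to 140000 nM.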

Compound 4, half-maximal inhibitory concentration: 22000 nM
The estimate for compound 4 lay 2.0-fold (0.31 log units) above the measured number; measured number inside the range.
By their numbers in this assay, from the lowest: compounds 4, 2, 3 and 1 (each within the scatter of the next, the first and the last beyond it).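

In this assay, the step of a 1.9-fold lower number from compound 2 to compound 4 (0.28 log units; within the scatter) shows that 4-chlorophenyl and 2-methoxyphenyl cannot be told apart on this amide-type nitrogen, even though 2-methoxyphenyl counts 1 hydrogen-bond acceptor and 4-chlorophenyl counts 0. For the compounds shown here, the step of a 4.0-fold lower number from compound 1 to compound 4 (0.60 log units; beyond the scatter) adds what the earlier compounds did not show: a second aryl group stands clear of 3-methoxyphenyl at this place, so compound 1 is now separated from both thioureas it can be compared with, although the size of that step remains modest. No measurement given here accounts for these differences.

What the compounds shown leave open is how far the aryl group on the thiourea nitrogen can be varied, since none of them carries a plain phenyl, a pyridyl ring, or an aryl group bearing an amine or a carboxylic acid. As far as these compounds go, the role of the thiocarbonyl also stays open, as compound 3 differs from each of the thioureas in more than one place, and so no urea and thiourea with the same aryl group can be compared.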